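The source may report more compounds than this note shows. Statements on the series, on what has been measured and on what is new or still open speak of the compounds shown alone.

Compound 1 `CCc1oc2ccccc2c1C(=O)c1cc(Br)c(OCc2cccc(OCC(=O)O)c2)c(Br)c1` gives 31% in an assay on HEK293 cells for inhibition of solute carrier family 22 member 12 (Homo sapiens), read by scintillation counting, with a stated time of 8 min, tested at 1000 nM; on this read-out lower numbers stand for a weaker effect and higher numbers for a stronger effect at the one concentration tested.
Compound 2 `CCc1oc2ccccc2c1C(=O)c1cc(Br)c(OCCCC(=O)O)c(Br)c1` gives 45% in this assay.

Compound 2 stands highest of the two numbers in this assay, and its nearest neighbour is compound 1, the difference being a number 14 percentage points higher from compound 1 to compound 2 (beyond the scatter). Compound 3 `CCc1oc2ccccc2c1C(=O)c1cc(Br)c(OCc2ccc(C(=O)O)cc2)c(Br)c1` is not yet measured. It differs from compound 2 by 4-carboxyphenyl in place of 2-carboxyethyl on a saturated chain carbon bound to an oxygen on an aromatic ring. Among the measured compounds shown here, the one measured step that bears on this is the step from compound 1 to compound 2, which exchanged an aromatic carboxy-bearing group for the 2-carboxyethyl chain and raised inhibition by a modest margin beyond the scatter. Compound 3 reverses that kind of exchange, returning an aromatic carboxy-bearing group at the same place, so a modest decrease in this assay is expected, roughly back toward the level of compound 1. The expected step is a number 12 percentage points lower from compound 2 to compound 3 (beyond the scatter). Compound 3 is therefore estimated at 33%, within a range from 18% to 48%.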

Compound 3, a percentage reported as inhibition, at one concentration (the size of the read-out at that concentration, not a potency): 23%
Beside the measured number, compound 3's estimate is 10 percentage points above it; measured number inside the range.
By their numbers in this assay, from the lowest: compounds 3 and 1 (each within the scatter of the next); then compound 2.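

In this assay, a second aromatic group carrying a carboxylic acid, placed on a saturated chain carbon bound to an oxygen on an aromatic ring, also falls short of the 2-carboxyethyl chain, with a number 22 percentage points lower from compound 2 to compound 3 (beyond the scatter). Between the two ring-bearing groups the comparison gives a number 8 percentage points lower from compound 1 to compound 3 (within the scatter), so 4-carboxyphenyl and 3-(carboxymethoxy)phenyl are not told apart here, and both stand on the same side of compound 2. Nothing measured here accounts for the gap between the chain and the ring-bearing groups.

Every group shown ends in a carboxylic acid, so it remains open whether an amide or an alcohol in its place would keep any of this inhibition. Also open, as far as these compounds go, is how a shorter or longer chain ending in a carboxylic acid would compare with the 2-carboxyethyl chain.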